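Swapping an amine for an ether on a shared core

This account rests on a few compounds, and the source may have more. Where it says the series, first, only, none or still open, it means among the compounds named here.

Compound 2 `COc1ccc(Cn2c(C(=O)N3CCN(Cc4ccccc4)CC3)cc3sc(CNC(C)c4ccccc4)cc32)cc1` and compound 1 `COc1ccc(Cn2c(C(=O)N3CCC(C(=O)NCc4cccc(Br)c4)CC3)cc3sccc32)cc1` were both tested in an ADME assay on HEK-293T cells (Homo sapiens) for cytotoxicity, read by luminescence, with a stated time of 24 h; a lower number here means that less compound is tolerated, a higher number that more compound is tolerated. Compound 1 reaches only the limit of the assay, recorded as > 100000 nM. Compound 2 likewise gives no number but a limit, > 100000 nM. On the numbers shown, compound 2 therefore stands at the ceiling of what was measured, a position summed up in the observation that both values sit at the limit of > 100000 nM in this assay, at which 2 of the 2 values shown sit, and no measured step between compounds exists to show how any structural change moves this read-out.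

Compound 3 `COc1ccc(Cn2c(C(=O)N3CCN(Cc4ccccc4)CC3)cc3sc(COCc4ccccc4)cc32)cc1` differs from compound 2 in one place: benzyloxy in place of (1-phenylethyl)amino on a saturated chain carbon bound to an aromatic carbon. Within the data shown here, with no measured step to lean on, the expected step is a number no higher from compound 2 to compound 3 (the limit leaves the size open), that is, none beyond the usual scatter. Compound 3 is accordingly expected to give around 100000 nM, within a range from 50000 nM to 300000 nM, most probably again reported only as a limit.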

Compound 3, half-maximal cytotoxic concentration: > 100000 nM
Compound 3: a limit, no number; the forecaster's own chance of this, stated with the estimate: 80%; the middle value sits exactly at the limit.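

No step can be read from compound 2 to compound 3, since neither gives a number, only a limit: the limit of > 100000 nM in this assay, at which 3 of the 3 values shown sit.

The compounds shown leave open how far benzyloxy in place of (1-phenylethyl)amino shifts the read-out in this assay, and what concentration of compound 1, compound 2 or compound 3 would harm these cells.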